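Phenyl for Trifluoromethyl on the Sulfonyl of Compound 1

The compounds below may be only part of what the source reports. "The series", "measured", "known", "first", "only" and "open" are said of these compounds alone.

Among the measured compounds shown here, compound 1 `C[n+]1ccn(CCCNS(=O)(=O)C(F)(F)F)c1/C=N/O` is one of two compounds measured in a physicochemical assay for lipophilicity (a lower number here means a more polar compound, a higher number a more lipophilic compound), and holds the lower of the two numbers: in this assay compound 1 gives -1.26. Its neighbour, compound 2 `CCN(CCCn1cc[n+](C)c1/C=N/O)S(=O)(=O)C(F)(F)F`, carries ethyl in place of hydrogen on the sulfonamide nitrogen and gives -1.02 in this assay; the step of a number 0.24 log units higher from compound 1 to compound 2 (within the scatter) is within the scatter, so the two compounds sit together rather than apart.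

Compound 3 `C[n+]1ccn(CCCNS(=O)(=O)c2ccccc2)c1/C=N/O` keeps the core of compound 1 and the unsubstituted sulfonamide nitrogen, and differs only in phenyl in place of trifluoromethyl on a sulfonyl sulfur. For the measured compounds named here, the one measured step, from compound 1 to compound 2, touches the sulfonamide nitrogen and not the sulfonyl sulfur, so it does not bear directly on this change; the data hold no step in which a group on the sulfonyl sulfur is exchanged. The change swaps a group of four heavy atoms and no ring for one of six heavy atoms forming one six-membered aromatic ring of carbon only, with no change in donors, acceptors or charge. For compound 3 a step of about a number 0.76 log units higher from compound 1 to compound 3 (beyond the scatter) upward in this assay is expected, and its value is estimated at -0.5, with a range from -1.1 to 0.1.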

Compound 3, distribution coefficient: -1.89
For compound 3 the middle estimate is 1.39 log units above the measured one; measured number outside the range, below it.
By their numbers in this assay, from the lowest: compound 3; then compounds 1 and 2 (each within the scatter of the next).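

On the sulfonyl sulfur, phenyl in place of trifluoromethyl moves the number in this assay downward, a number 0.63 log units lower from compound 1 to compound 3 (beyond the scatter), the opposite direction to the upward step that had been expected for this exchange. Among the compounds shown here, this position therefore registers a change beyond the scatter, whereas the only earlier step, at the sulfonamide nitrogen, was a number 0.24 log units higher from compound 1 to compound 2 (within the scatter), so the group on the sulfonyl sulfur is the first place in this small set where a single exchange separates two compounds in this read-out. Nothing available accounts for why the entering group, with its larger count of heavy atoms and its aromatic ring of carbon only, gives the lower number.

From the compounds shown here alone, all of this rests on one pair, so it remains open whether other groups on the sulfonyl sulfur, such as methyl, a longer alkyl chain or a phenyl ring carrying a carboxylic acid or an amine, would fall on the same side of compound 1. Also open, going by these compounds, is whether ethyl on the sulfonamide nitrogen would leave the number as little changed when phenyl rather than trifluoromethyl sits on the sulfonyl sulfur.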